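The compounds below may be only part of what the source reports. "The series", "measured", "known", "first", "only" and "open" are said of these compounds alone.

Three compounds share one core and differ in the group carried on the saturated six-membered ring and in the substituent on the distant phenyl ring. Compound 1 `C/C(=C\C(=O)Nc1ccc2nc(N3CCC(O)(C4CC4)CC3)nc(C)c2c1)c1ccc(Cl)cc1` gives 532 nM in an assay on CHO-K1 cells for displacement of a labelled ligand from melanin-concentrating hormone receptor 1 (Homo sapiens), read by scintillation proximity assay, with a stated time of 2 h; a higher number here means a weaker inhibitor, a lower number a stronger inhibitor. Compound 3 `COCCC1(O)CCN(c2nc(C)c3cc(NC(=O)/C=C/c4ccc(Cl)cc4)ccc3n2)CC1` gives 245 nM in this assay. Compound 2 `Cc1nc(N2CCC(NS(=O)(=O)N(C)C)CC2)nc2ccc(NC(=O)/C=C/c3ccc(OC(F)(F)F)cc3)cc12` gives 105 nM in this assay, the lowest number of the three; its gaps to compound 3 and to compound 1 both lie beyond the usual scatter, so compound 2 is the strongest inhibitor among them.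

Compound 4 `Cc1nc(N2CCC(N3CCOC3=O)CC2)nc2ccc(NC(=O)/C=C/c3ccc(OC(F)(F)F)cc3)cc12` has not been measured. It differs from compound 2 in one place: 2-oxo-1,3-oxazolidin-3-yl in place of (dimethylsulfamoyl)amino on a saturated ring carbon. Going by the values given here, no pair of measured compounds isolates this exchange, and compounds 1 and 3 carry other groups on that ring carbon together with a different phenyl substituent, so they give no clean guide. The step of a 1.5-fold higher number from compound 2 to compound 4 (0.18 log units; within the scatter) is expected to be modest, at most slightly toward a weaker inhibitor, and possibly within the scatter. Compound 4 is therefore expected to give about 160 nM in this assay, with a plausible range from 50 nM to 500 nM.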

Compound 4, half-maximal inhibitory concentration: 41 nM
Compound 4: the middle estimate sits 3.9-fold (0.59 log units) above what was measured; the measured number lies below the stated range.
By their numbers in this assay, from the lowest: compound 4; then compound 2; then compound 3; then compound 1.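

Exchanging (dimethylsulfamoyl)amino for 2-oxo-1,3-oxazolidin-3-yl on this saturated ring carbon gives a 2.6-fold lower number from compound 2 to compound 4 (0.41 log units; beyond the scatter) in this assay, showing that the number responds to the group at this position. The group that leaves carries a hydrogen-bond donor and the group that enters carries none, so a donor on this carbon is not required for the lower number in this series. No measurement shown here accounts for the change.

The exchange also adds a ring, so the compounds shown cannot separate the effect of the ring from that of losing the donor; an N-methylacetamide group, with no ring and no hydrogen-bond donor, would help tell them apart. On these data alone, it also remains open whether the exchange gives a similar step with the chloro substituent that compound 1 and compound 3 carry on the distant phenyl ring.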